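Methoxy to Hydroxy on a Shared Core: An Expectation

A few compounds are considered here, and "the series" means these few. Any claim that something is new, unique, unknown or untested is made for them only; others in the source may bear on it.

Of the compounds shown here, three built on one shared core have been measured in a functional assay on NCI-H322M cells (Homo sapiens) for inhibition, read by sulforhodamine B assay, with a stated time of 48 h, tested at 0.01 uM; on this read-out lower numbers stand for a stronger effect and higher numbers for a weaker effect at the one concentration tested. Compound 1 `COc1cc(Cl)cc(-c2nn(-c3cccc(NC(=O)Nc4cccc(C(F)(F)F)c4)c3)cc2-c2ccncc2)c1` gives 99%, compound 2 `COc1cc(Cl)cc(-c2nn(-c3cccc(NC(=O)Nc4ccc(Cl)c(C(F)(F)F)c4)c3)cc2-c2ccncc2)c1` gives 96%, and compound 3 `COc1cc(Cl)cc(-c2nn(-c3cccc(NC(=O)c4cccc(C(F)(F)F)c4)c3)cc2-c2ccncc2)c1` gives 69%. Compound 2 stands second highest of the three numbers, with compound 1 nearest and compound 3 furthest; the step of a number 3 percentage points lower from compound 1 to compound 2 (within the scatter) lies within the scatter, while a number 27 percentage points lower from compound 2 to compound 3 (beyond the scatter) and a number 30 percentage points lower from compound 1 to compound 3 (beyond the scatter) lie beyond it.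

Compound 4 `O=C(Nc1cccc(-n2cc(-c3ccncc3)c(-c3cc(O)cc(Cl)c3)n2)c1)Nc1ccc(Cl)c(C(F)(F)F)c1` differs from compound 2 in a single place: hydrogen in place of methyl on an oxygen on an aromatic ring. Among the measured compounds shown here, none of the measured steps bears on that oxygen: a number 3 percentage points lower from compound 1 to compound 2 (within the scatter) concerns a chloro on an aromatic carbon, and a number 30 percentage points lower from compound 1 to compound 3 (beyond the scatter) together with a number 27 percentage points lower from compound 2 to compound 3 (beyond the scatter) concerns the carbonyl carbon. The data thus give no direct guide for removing a methyl from this oxygen. With only one heavy atom leaving and no ring involved, the step of a number 4 percentage points lower from compound 2 to compound 4 (within the scatter) is expected to stay within the scatter. Compound 4 is estimated at 92% in this assay, with a range from 78% to 100%.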

Compound 4, a percentage reported as activity, at one concentration (the size of the read-out at that concentration, not a potency): 107%
Compound 4: the middle estimate sits 15 percentage points below what was measured; the whole stated range lies below it.
By their numbers in this assay, from the lowest: compound 3; then compounds 2, 1 and 4 (each within the scatter of the next, the first and the last beyond it).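

In this assay, replacing methoxy with hydroxy on the 3-chloro-5-methoxyphenyl group gives a number 11 percentage points higher from compound 2 to compound 4 (beyond the scatter), which means a weaker effect at the one concentration tested. This shows that the oxygen on the aromatic ring is a place where the read-out responds to the loss of a single methyl, whereas the earlier step beyond the scatter at another place, on the carbonyl carbon, ran towards a stronger effect. Nothing available accounts for this step.

The compounds shown leave open how a longer chain on this oxygen, such as ethoxy, or an amine in place of the methoxy would read. From the compounds shown here alone, with a single pair carrying this change, it also remains open whether hydroxy would act the same way on the core of compound 1 or compound 3.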